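Swapping a Phenethyl Group for a Methoxyphenoxy Group

A few compounds are considered here, and "the series" means these few. Any claim that something is new, unique, unknown or untested is made for them only; others in the source may bear on it.

Of the compounds shown here, three sharing one core have so far been tested in a physicochemical assay for solubility, with a stated time of 18 h, at pH 7.4; on this read-out lower numbers stand for lower solubility and higher numbers for higher solubility. Compound 1 `COc1ccc(F)cc1CNCCCNc1ccnc2cc(C3CCCCC3)ccc12` gives 4200 nM in this assay. Compound 2 `CC(C)Cc1ccc2c(NCCCNCc3ccco3)ccnc2c1` gives 4200 nM in this assay. Compound 3 `c1ccc(CCc2ccc3c(NCCCNCc4ccco4)ccnc3c2)cc1` gives 4200 nM in this assay. Compound 3 therefore stands level with compounds 1 and 2 at the digits shown, and no order among the three can be read from these numbers. Going by the values given here, the only step in the set that changes a single place is no change at the digits printed from compound 2 to compound 3 (within the scatter), a benzyl in place of isopropyl on a saturated chain carbon bound to an aromatic carbon, and it left the solubility unmoved within the scatter.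

Compound 4 `COc1ccccc1Oc1ccc2c(NCCCNCc3ccco3)ccnc2c1` has not yet been measured. It differs from compound 3 in one place: 2-methoxyphenoxy in place of phenethyl on an aromatic carbon. Among the compounds with values here, no measured step replaces a group on an aromatic carbon of the core, so nothing in the data points to a move in either direction, while no change at the digits printed from compound 2 to compound 3 (within the scatter) shows that a change of similar size in this set gave no change. Compound 4 is accordingly expected to show no change at the digits printed from compound 3 to compound 4 (within the scatter), a step within the scatter. For compound 4 the estimated solubility in this assay is 4200 nM, expected to fall between 2000 nM and 8500 nM.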

Compound 4, solubility: 14500 nM
For compound 4 the middle estimate is 3.5-fold (0.54 log units) below the measured one; measured number outside the range, above it.
By their numbers in this assay, from the lowest: compounds 1, 2 and 3 (each within the scatter of the next); then compound 4.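

In this assay, this aromatic carbon of the shared core turns out to be a place where a swap can move the number: 2-methoxyphenoxy in place of phenethyl gives a 3.5-fold higher number from compound 3 to compound 4 (0.54 log units; beyond the scatter), and 2-methoxyphenoxy in place of isobutyl gives a 3.5-fold higher number from compound 2 to compound 4 (0.54 log units; beyond the scatter). The earlier swap at this place, benzyl for isopropyl on the saturated chain carbon, gave no change at the digits printed from compound 2 to compound 3 (within the scatter), so a larger group ending in an aromatic ring was not enough on its own to separate two compounds here. Phenethyl and 2-methoxyphenoxy each carry one six-membered aromatic ring of carbon only, and what differs in the count is the atoms around that ring: 2-methoxyphenoxy brings 2 oxygen atoms and 2 hydrogen-bond acceptors, where phenethyl has none.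

No measurement shown here explains why the number went up. From the compounds shown here alone, the swap changes the linking atoms and adds a methoxy group in one move, so it remains open which part carries the step, and whether a plain phenoxy, an amine or a carboxylic acid at this place would stand with compound 4 or with compound 3.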